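Hydroxy in Place of Fluoro: From Compound 3 to Compound 4

The source may report more compounds than this note shows. Statements on the series, on what has been measured and on what is new or still open speak of the compounds shown alone.

Compound 1 `COc1cc(/C=C/c2ccc(S(N)(=O)=O)cc2)cc(OC)c1`: 17400 nM
Compound 2 `COc1cccc(/C=C/c2ccc(S(N)(=O)=O)cc2)c1`: 3600 nM
Compound 3 `NS(=O)(=O)c1ccc(/C=C/c2ccc(F)cc2)cc1`: 9980 nM

In a functional assay on HCT-15 cells (Homo sapiens) for inhibition (on this read-out higher numbers stand for weaker inhibition of growth and lower numbers for stronger inhibition of growth), compound 3 gives 9980 nM, the second highest of the three numbers; its gap to compound 1 is within the scatter, its gap to compound 2 is beyond it. Compound 4 `NS(=O)(=O)c1ccc(/C=C/c2ccc(O)cc2)cc1` differs from compound 3 in one place: hydroxy in place of fluoro on an aromatic carbon. For the measured compounds named here, the only measured step, a 4.8-fold lower number from compound 1 to compound 2 (0.68 log units; beyond the scatter), concerns a methoxy on a different ring and does not bear on a hydroxy in place of fluoro, so no measured step guides this change. For compound 4 the expected outcome is a step of a 1.2-fold lower number from compound 3 to compound 4 (0.10 log units; within the scatter), not beyond the scatter. Compound 4 is therefore estimated at 8000 nM, in the range 2500 nM to 25000 nM.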

Compound 4, concentration for 50% growth inhibition: 24600 nM
For compound 4 the middle estimate is 3.1-fold (0.49 log units) below the measured one; the measured number falls inside the stated range.
By their numbers in this assay, from the lowest: compound 2; then compounds 3, 1 and 4 (each within the scatter of the next, the first and the last beyond it).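

At this position, para to a large group, hydroxy in place of fluoro gives a 2.5-fold higher number from compound 3 to compound 4 (0.39 log units; beyond the scatter) in this assay, a change towards weaker inhibition of growth. For the compounds shown here, the position is therefore not indifferent to the group it carries, which the earlier compounds could not show. The change adds a hydrogen-bond donor and acceptor, but nothing available accounts for the step. The compounds shown leave open whether an amine or a carboxylic acid at this position would give a higher or a lower number than fluoro or hydroxy.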